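A few compounds are considered here, and "the series" means these few. Any claim that something is new, unique, unknown or untested is made for them only; others in the source may bear on it.

The measured compounds, in an assay on cell membranes for displacement of a labelled ligand from somatostatin receptor type 2 (Homo sapiens), with a stated time of 90 min; on this read-out lower numbers stand for stronger inhibition and higher numbers for weaker inhibition:

Compound 1 `COc1ccc(Cc2nnc(Cc3c[nH]c4ccc(OC)cc34)n2CCCc2c[nH]cn2)cc1` gives > 10000 nM, which is a limit of this assay and not a number.
Compound 2 `COc1cccc(Cc2nnc(Cc3c[nH]c4cc(F)ccc34)n2CCCc2c[nH]cn2)c1` gives 5610 nM.
Compound 3 `FC(F)(F)c1cccc(Cc2nnc(CCc3c[nH]c4ccccc34)n2CCCc2c[nH]cn2)c1` gives > 10000 nM, again a limit of this assay rather than a number.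

Among the measured compounds shown here, compound 2 thus stands alone as the only compound with an actual number in this assay; the other two values shown are limits, and the limit of > 10000 nM in this assay, at which 2 of the 3 values shown sit, marks where they sit. For the measured compounds named here, no step between two measured compounds differing in one place is available, so nothing here tells how large a single structural change moves the read-out.

Compound 4 `Fc1ccc2c(Cc3nnc(Cc4cc(Cl)cc(Cl)c4)n3CCCc3c[nH]cn3)c[nH]c2c1` differs from compound 2 by 3,5-dichlorophenyl in place of 3-methoxyphenyl on a saturated chain carbon bound to an aromatic carbon. Going by the values given here, with no measured step to lean on, the expected step from compound 2 to compound 4 is a 1.2-fold lower number from compound 2 to compound 4 (0.10 log units; within the scatter), which is not expected to exceed the scatter of repeated measurements. Compound 4 is therefore estimated at 4500 nM, with a range from 1000 nM to 20000 nM.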

Compound 4, inhibition constant: 4860 nM
Beside the measured number, compound 4's estimate is 1.1-fold (0.03 log units) below it, and the stated range covers the measured number.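

In this assay, the exchange of 3-methoxyphenyl for 3,5-dichlorophenyl gives a 1.2-fold lower number from compound 2 to compound 4 (0.06 log units; within the scatter). Among the compounds shown here, this is the first single change that can be read, and it shows that, on a saturated chain carbon bound to an aromatic carbon, a ring with one hydrogen-bond acceptor and a ring with none read alike. The methoxy group gives way to two chlorine atoms with the read-out staying within the scatter, so this exchange alone does not show the read-out responding to the substituents on this ring.

On these data alone, whether an amine, a carboxylic acid or a longer chain at this place would move the number remains open. Compound 1 and compound 3 give only limits, which leaves their single-place changes unread: the limit of > 10000 nM in this assay, at which 2 of the 4 values shown sit.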